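The source may report more compounds than this note shows. Statements on the series, on what has been measured and on what is new or still open speak of the compounds shown alone.

Measured so far:
- compound 1, `CCOCCC(=O)NCC(=O)N[C@@H]1[C@@H](O)[C@H](O)[C@@H](Nc2ncnc3[nH]cnc23)O[C@H]1CO`: > 500000 nM in a functional assay on L1210 cells (Mus musculus) for cytotoxicity; on this read-out lower numbers stand for stronger inhibition and higher numbers for weaker inhibition
- compound 2, `CCCCCCCCCCCCCCCC(=O)NCC(=O)N[C@@H]1[C@@H](O)[C@H](O)[C@@H](Nc2ncnc3[nH]cnc23)O[C@H]1CO`: > 100000 nM in this assay

Neither of these is a true number. The value of compound 1 in this assay is a limit of the assay, not a measured concentration. The value of compound 2 in this assay is likewise a limit. So compound 2 cannot be placed on a scale at all: it sits at the limit of > 100000 nM in this assay, at which 1 of the 2 values shown sits, and the only other compound shown sits at the limit of > 500000 nM in this assay, at which 1 of the 2 values shown sits. Among the measured compounds shown here, no pair of measured compounds differs in one place, so no step between measured compounds is available as a guide.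

Compound 3, `CCCCCCCCCCCC(=O)NCC(=O)N[C@@H]1[C@@H](O)[C@H](O)[C@@H](Nc2ncnc3[nH]cnc23)O[C@H]1CO`, differs from compound 2 by hydrogen in place of butyl on a saturated chain carbon, ten or more bonds along the chain from a carbonyl carbon. With both measured compounds showing only limits, there is nothing to suggest that shortening the chain in this way would bring compound 3 into the range where a number is read. The step from compound 2 to compound 3 is therefore expected to be none beyond the scatter, a step that the limit leaves unreadable from compound 2 to compound 3. Compound 3 is estimated at 200000 nM, with a range from 50000 nM to 1000000 nM, and most likely only a limit will be reported.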

Compound 3, half-maximal inhibitory concentration: 3000 nM
Compound 3: middle estimate off by 67-fold (1.82 log units), on the high side; measured number below the stated range.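

In this assay compound 3 gives 3000 nM, the only true number among the compounds shown, and hydrogen in place of butyl on a saturated chain carbon, ten or more bonds along the chain from a carbonyl carbon, amounts to an at least 33-fold lower number from compound 2 to compound 3 (1.52 log units; beyond the scatter). So this far along the chain, the change decides whether a number can be read at all, and adding chain length does not simply strengthen the inhibition. Nonyl in place of ethoxy on a saturated chain carbon, two bonds along the chain from a carbonyl carbon, amounts to an at least 160-fold lower number from compound 1 to compound 3 (2.22 log units; beyond the scatter), so among these three compounds a number appears only with the chain of compound 3, and compound 2, with the longest chain, goes against any rule that longer is better.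

As far as these compounds go, both steps are minimum sizes, and their true sizes stay open, since the values of compound 1 and compound 2 are limits and not numbers. Also open, from the compounds shown here alone, is how the read-out changes with a chain shorter than that of compound 3 but carrying no ether oxygen, such as hexyl, or with an amine or a carboxylic acid on the chain.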